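This account rests on a few compounds, and the source may have more. Where it says the series, first, only, none or still open, it means among the compounds named here.

In a physicochemical assay for acid dissociation, compound 1 `COc1cccc(CNCCCNc2ccnc3cc(Oc4ccccc4)ccc23)c1O` gives 9.28. Compound 3 `c1ccc(Oc2ccc3c(NCCCNCc4ccco4)ccnc3c2)cc1` gives 9.28 in this assay, and compound 2 `c1ccc(CCc2ccc3c(NCCCNCc4ccco4)ccnc3c2)cc1` gives 9.47. Compound 1 stands level with compound 3 at the digits shown, and together they are the lowest of the three numbers; its furthest neighbour is compound 2, a gap that stays within the scatter. Two single changes connect these three compounds. no change at the digits printed from compound 1 to compound 3 (within the scatter), so exchanging the group bound to the amine nitrogen on the saturated chain carbon left the number where it was. a number 0.19 log units lower from compound 2 to compound 3 (within the scatter), so exchanging the group on the aromatic carbon of the fused core also left the number essentially unmoved.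

Compound 4 `COc1cccc(CNCCCNc2ccnc3cc(CC(C)C)ccc23)c1O` has not been measured yet. It differs from compound 1 in one place: isobutyl in place of phenoxy on an aromatic carbon. Among the measured compounds shown here, the measured step that bears on this is the one from compound 2 to compound 3, which also exchanges the group on that same aromatic carbon and stayed within the scatter. The exchange for compound 4 is of a similar kind, so no shift beyond the scatter is expected. Compound 4 is therefore expected to give about 9.4 in this assay, within a range of 9.05 to 9.75. This estimate means an expected step of a number 0.12 log units higher from compound 1 to compound 4 (within the scatter).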

Compound 4, acid dissociation constant: 9.47
Compound 4: the middle estimate sits 0.07 log units below what was measured; low and high end bracket the measured number.
By their numbers in this assay, from the lowest: compounds 1, 3, 2 and 4 (each within the scatter of the next).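

The step of a number 0.19 log units higher from compound 1 to compound 4 (within the scatter) extends what is known about this aromatic carbon, the one meta to a fused ring and para to a fused ring, in this assay in two ways. The earlier step at this carbon exchanged phenethyl and phenoxy, two groups that both carry a six-membered aromatic ring of carbon only, whereas this one replaces phenoxy, with 7 heavy atoms, a ring and a hydrogen-bond acceptor, by isobutyl, with 4 heavy atoms, no ring and no hydrogen-bond acceptor, and the number still stays within the scatter. It also moves the question from compounds with furan-2-yl on the chain to a compound with 2-hydroxy-3-methoxyphenyl there, and the same outcome holds, although nothing shown here accounts for it.

As far as these compounds go, whether this holds for every kind of group at this carbon stays open, as a group carrying an amine or a carboxylic acid there could still shift the number beyond the scatter. Also open, from the compounds shown here alone, is whether isobutyl at this carbon would give a similar number with furan-2-yl on the chain.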